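Working notes: compound 3 against the two measured analogues

This account rests on a few compounds, and the source may have more. Where it says the series, first, only, none or still open, it means among the compounds named here.

Going by the values given here, compound 2 `c1ccc2c(c1)CN[C@@H](CN(CCCCNC1CCNCC1)[C@H]1CCCc3cccnc31)C2` gives 63.4 nM in a functional assay on cells for antagonist activity at C-X-C chemokine receptor type 4 (Homo sapiens), read by fluorescence and calcium flux, with stated times of 25 min and 90 s (a lower number here means a stronger inhibitor, a higher number a weaker inhibitor), and holds the highest of the two numbers so far; the nearest is compound 1 `c1ccc2c(c1)CN[C@@H](CN(CCCCNCC1CCNCC1)[C@H]1CCCc3cccnc31)C2`, which in this assay gives 36.5 nM, and the step of a 1.7-fold higher number from compound 1 to compound 2 (0.24 log units; within the scatter) lies within the scatter. Compound 3 `NCc1ccccc1CN(C[C@H]1Cc2ccccc2CN1)[C@H]1CCCc2cccnc21` differs from compound 2 by a group of 8 heavy atoms (7 carbon, 1 nitrogen; one six-membered aromatic ring of carbon only) in place of a group of 10 heavy atoms (8 carbon, 2 nitrogen; one six-membered non-aromatic ring with 1 hetero atom), on a saturated chain carbon bound to an amine nitrogen. Among the compounds with values here, the only measured step, from compound 1 to compound 2, concerns a change elsewhere on the shared core and is small, so no measured step bears directly on the change to compound 3; its size in this assay cannot be read from the series, and the expectation rests on compound 2 alone. For compound 3 the estimate in this assay is therefore 70 nM, with a range of 15 nM to 300 nM. The estimated step of a 1.1-fold higher number from compound 2 to compound 3 (0.04 log units; within the scatter) is meant to stay within the scatter around compound 2, the range being kept wide.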

Compound 3, half-maximal inhibitory concentration: 50.8 nM
Compound 3: the middle estimate sits 1.4-fold (0.14 log units) above what was measured; measured number inside the range.
By their numbers in this assay, from the lowest: compounds 1, 3 and 2 (each within the scatter of the next).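

In this assay, 2-(aminomethyl)phenyl on a saturated chain carbon bound to an amine nitrogen holds the number within the scatter of both earlier compounds: a 1.2-fold lower number from compound 2 to compound 3 (0.10 log units; within the scatter) and a 1.4-fold higher number from compound 1 to compound 3 (0.14 log units; within the scatter). The earlier pair changed only piperidin-4-yl against (piperidin-4-yl)methyl, whereas this change shows that a six-membered aromatic ring of carbon only can take the place of the six-membered non-aromatic ring with 1 hetero atom without a step beyond the scatter. No supporting measurement explains this outcome.

Going by these compounds, it remains open how a plain phenyl or a 2-(hydroxymethyl)phenyl would read in this assay, and thus whether the amine of the aminomethyl group matters. Also open, on these data alone, is how 2-(2-aminoethyl)phenyl, with its longer chain, would read.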